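Sulfanyl substituent variation on a shared core: notes

A few compounds are considered here, and "the series" means these few. Any claim that something is new, unique, unknown or untested is made for them only; others in the source may bear on it.

Measured so far:
compound 1, `Cc1cc(N2CC[C@@H](C)[C@@H](N(C)c3ncnc4[nH]ccc34)C2)n2nc(SCC3CC3)nc2n1`, 36500 nM in a functional assay on BGC-823 cells (Homo sapiens) for inhibition, read by MTT assay, with a stated time of 72 h; on this read-out lower numbers stand for stronger inhibition and higher numbers for weaker inhibition
compound 2, `Cc1cc(N2CC[C@@H](C)[C@@H](N(C)c3ncnc4[nH]ccc34)C2)n2nc(SCc3ccccc3Br)nc2n1`, 81100 nM
compound 3, `Cc1cc(N2CC[C@@H](C)[C@@H](N(C)c3ncnc4[nH]ccc34)C2)n2nc(SCc3ccc(F)c(Cl)c3)nc2n1`, 98900 nM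

Compound 3 has the highest number of the three in this assay. Its separation from compound 1 is clear, a 2.7-fold higher number from compound 1 to compound 3 (0.43 log units; beyond the scatter), whereas against compound 2 it is not resolved, a 1.2-fold higher number from compound 2 to compound 3 (0.09 log units; within the scatter). Replacing cyclopropyl on the saturated chain carbon bound to sulfur by an aromatic group has twice given a modest rise: a 2.2-fold higher number from compound 1 to compound 2 (0.35 log units; beyond the scatter) and a 2.7-fold higher number from compound 1 to compound 3 (0.43 log units; beyond the scatter).

Compound 4 is `Cc1cc(N2CC[C@@H](C)[C@@H](N(C)c3ncnc4[nH]ccc34)C2)n2nc(SCCCc3ccccc3)nc2n1`. It differs from compound 3 as follows: phenethyl in place of 3-chloro-4-fluorophenyl on a saturated chain carbon bound to a sulfur. The aromatic ring is kept, its halogens are removed, and the chain to sulfur is one carbon longer. Within the data shown here, the only step bearing directly on an aryl-to-aryl exchange at this position is the one from compound 2 to compound 3, which stayed within the scatter. Among the measured compounds shown here, no measured step covers lengthening of the chain, so that part of the change cannot be anchored on these data.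

On that basis the number for compound 4 is expected to remain close to that of compound 3, an estimated step of a 1.2-fold lower number from compound 3 to compound 4 (0.09 log units; within the scatter), with the estimate for compound 4 at 80000 nM and a range of 35000 nM to 200000 nM.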

Compound 4, half-maximal inhibitory concentration: > 100000 nM
Compound 4: a limit, no number (the forecaster's own chance of this, stated with the estimate: 10%); middle value at least 1.2-fold (0.09 log units) away from the limit.
By their numbers in this assay, from the lowest: compound 1; then compounds 2 and 3 (each within the scatter of the next). At a limit, above all of these: compound 4.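

In this assay, compound 4 is read at a limit and not at a number: the limit of > 100000 nM in this assay, at which 1 of the 4 values shown sits. Even so, the limit shows that the rise over the cyclopropyl group is not confined to the two halogenated benzyl groups, since (3-phenylpropyl)sulfanyl, whose ring carries no halogen, also lies on the higher side: an at least 2.7-fold higher number from compound 1 to compound 4 (0.43 log units; beyond the scatter). Against the 2-bromophenyl group the result is not resolved, with an at least 1.2-fold higher number from compound 2 to compound 4 (0.09 log units; that floor lies within the scatter), and the size of the step from the 3-chloro-4-fluorophenyl group cannot be read, with a number no lower from compound 3 to compound 4 (the limit leaves the size open), so these data do not show whether the longer chain with its unsubstituted ring gives any further rise over the halogenated groups.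

The change to compound 4 removes the halogens and lengthens the chain together, so the two remain inseparable here, and an unsubstituted benzyl group on the sulfur would be needed to tell them apart. As far as these compounds go, it also remains open whether an amine or a carboxylic acid on the chain bound to sulfur would give a number lower than that of compound 1, at 36500 nM.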